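Urea series: chloro to methoxy step, compound 3 to compound 4

This account rests on a few compounds, and the source may have more. Where it says the series, first, only, none or still open, it means among the compounds named here.

Measured so far:
compound 1 `COc1ccc(NC(=O)Nc2nc(Sc3c[nH]c4ccccc34)cc(N3CCCCC3)n2)cc1` 17400 nM
compound 2 `COc1ccc(NC(=O)Nc2nc(Sc3c[nH]c4ccccc34)cc(N3CCN(c4ccccn4)CC3)n2)cc1` 33400 nM
compound 3 `O=C(Nc1ccc(Cl)cc1)Nc1nc(Sc2c[nH]c3ccccc23)cc(N2CCCC2)n1` 10400 nM

In a functional assay on PC-3 cells (Homo sapiens) for inhibition, with a stated time of 72 h (on this read-out higher numbers stand for weaker inhibition and lower numbers for stronger inhibition), compound 3 stands lowest of the three numbers; compound 1 lies within the scatter of it, compound 2 beyond it. Compound 4 `COc1ccc(NC(=O)Nc2nc(Sc3c[nH]c4ccccc34)cc(N3CCCC3)n2)cc1` differs from compound 3 by methoxy in place of chloro on an aromatic carbon. Among the measured compounds shown here, no measured step bears on this change: the only step, a 1.9-fold higher number from compound 1 to compound 2 (0.28 log units; within the scatter), concerns the ring attached to the shared core, and compounds 1 and 3 differ in two places, their values within the scatter of each other. No step beyond the scatter is therefore expected. Compound 4 is estimated at 14000 nM (range 5000 nM to 40000 nM), which is expected to mean a 1.3-fold higher number from compound 3 to compound 4 (0.13 log units; within the scatter).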

Compound 4, half-maximal inhibitory concentration: 21500 nM
Compound 4: middle estimate off by 1.5-fold (0.19 log units), on the low side; the measured number falls inside the stated range.
By their numbers in this assay, from the lowest: compounds 3, 1, 4 and 2 (each within the scatter of the next, the first and the last beyond it).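

In this assay, among the compounds shown here, the step at this position reads a 2.1-fold higher number from compound 3 to compound 4 (0.32 log units; beyond the scatter) for methoxy in place of chloro, a modest step beyond the scatter and the first direct reading of this change. The ring on the shared core gives a 1.6-fold lower number from compound 2 to compound 4 (0.19 log units; within the scatter) and a 1.2-fold higher number from compound 1 to compound 4 (0.09 log units; within the scatter) with both steps within the scatter, so these ring changes do not separate the compounds. Nothing available bears on the reason for the chloro to methoxy step.

Open, as far as these compounds go, is where a fluoro, a methyl or an amine at the same place would fall relative to chloro and methoxy. Also open, from the compounds shown here alone, is whether the chloro to methoxy step holds with piperidin-1-yl on the shared core.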